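Swapping a trifluoromethyl for an octyl ester

A few compounds are considered here, and "the series" means these few. Any claim that something is new, unique, unknown or untested is made for them only; others in the source may bear on it.

Of the compounds shown here, two have been tested in an assay on Jurkat cells for inhibition of cyclic AMP-dependent transcription factor ATF-1 (Homo sapiens); a lower number here means a stronger inhibitor, a higher number a weaker inhibitor. Compound 1, `O=C(Nc1cc(Cl)cc(Cl)c1)c1cncnc1C(F)(F)F`, yields only a limit in this assay, namely > 10000 nM, which is the limit of > 10000 nM in this assay, at which 1 of the 2 values shown sits. Going by the values given here, compound 2, `O=C(Nc1cc(C(F)(F)F)cc(C(F)(F)F)c1)c1cnc(Cl)nc1C(F)(F)F`, gives 50 nM in this assay, and it therefore holds the only real number among the two values shown. Compound 3, `CCCCCCCCOC(=O)c1cc(NC(=O)c2cnc(Cl)nc2C(F)(F)F)cc(C(F)(F)F)c1`, has not been measured yet. From compound 2 to compound 3 the change is octyloxycarbonyl in place of trifluoromethyl on an aromatic carbon. Among the compounds with values here, no step between two measured compounds exists here, so there is no measured change of comparable kind to lean on, and the expectation rests on compound 2 alone, whose value in this assay is 50 nM. Compound 3 is estimated at 200 nM in this assay, within a range from 30 nM to 1500 nM. The expected step of a 4.0-fold higher number from compound 2 to compound 3 (0.60 log units; beyond the scatter) is thus a loss somewhat beyond the usual scatter, though with wide uncertainty.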

Compound 3, half-maximal inhibitory concentration: 1200 nM
The estimate for compound 3 lay 6.0-fold (0.78 log units) below the measured number; the measured number falls inside the stated range.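

Going by these compounds alone, this is the first measured change at this position on the aromatic ring: in this assay, octyloxycarbonyl in place of trifluoromethyl gives a 24-fold higher number from compound 2 to compound 3 (1.38 log units; beyond the scatter), a large loss. Even so, compound 3 still gives a real number, 1200 nM, so a group of 11 heavy atoms, against 4 for trifluoromethyl and now carrying 2 hydrogen-bond acceptors, leaves measurable inhibition at this position. Nothing measured here shows why the number rises.

The compounds shown leave open whether the loss goes with the ester itself or with the length of the octyl chain. A methyl ester, a carboxylic acid or an amine on the same aromatic carbon, each set against compound 2, would help to separate these two possibilities.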